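The source may report more compounds than this note shows. Statements on the series, on what has been measured and on what is new or still open speak of the compounds shown alone.

In a functional assay on HCT-116 cells (Homo sapiens) for inhibition, read by colorimetric assay, with a stated time of 3 days (on this read-out higher numbers stand for weaker inhibition and lower numbers for stronger inhibition), compound 2 `O=C(CCCCCCNC(=O)C(O)(O)C(F)(F)F)Nc1nc2ccccc2o1` gives 3450 nM, the lowest of the two numbers on hand. Compound 3 `O=C(CCCCCCNC(=O)C(O)(O)C(F)(F)F)Nc1nc2ccc(Br)cc2o1`, which carries a bromo in place of hydrogen on an aromatic carbon, gives 12100 nM, and the step of a 3.5-fold higher number from compound 2 to compound 3 (0.54 log units; beyond the scatter) is beyond the scatter. Compound 1 `O=C(CCCCCCNC(=O)c1cc(=O)c(O)co1)Nc1ccccc1` gives only a limit of the assay, > 100000 nM, and so contributes no number. Compound 4 `O=C(CCCCCCNC(=O)C(O)(O)C(F)(F)F)Nc1nccs1` differs from compound 2 by 1,3-thiazol-2-yl in place of 1,3-benzoxazol-2-yl on an amide-type nitrogen. Going by the values given here, no measured step touches the group on the amide-type nitrogen, and the single measured change to the shared core, the bromo on an aromatic carbon, brought a modest loss. A modest loss is therefore expected for the step of a 2.3-fold higher number from compound 2 to compound 4 (0.37 log units; beyond the scatter). For compound 4 the estimate is 8000 nM, with a range from 2500 nM to 30000 nM.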

Compound 4, half-maximal inhibitory concentration: 10800 nM
For compound 4 the middle estimate is 1.4-fold (0.13 log units) below the measured one; the range from low to high includes it.
By their numbers in this assay, from the lowest: compound 2; then compounds 4 and 3 (each within the scatter of the next). At a limit, above all of these: compound 1.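

In this assay, going by these compounds alone, putting 1,3-thiazol-2-yl in place of 1,3-benzoxazol-2-yl on the amide-type nitrogen gives a 3.1-fold higher number from compound 2 to compound 4 (0.50 log units; beyond the scatter), a modest loss of inhibition at a place no earlier step had touched. Inhibition therefore responds to this group but survives without its six-membered aromatic ring of carbon only, although the step also trades oxygen for sulfur. Nothing measured here gives a cause for this step.

Going by these compounds, it remains open whether the ring or the sulfur accounts for the loss. A 1,3-benzothiazol-2-yl group on this nitrogen, keeping both, would begin to separate them.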